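The compounds below may be only part of what the source reports. "The series", "measured", "known", "first", "only" and "open" are said of these compounds alone.

Compound 1, with structure `CC1(C)C(=O)Nc2ccc(OCCOc3ccccc3)cc21`, was tested in an assay on cells for inhibition of Amine oxidase [flavin-containing] B (Homo sapiens), read by fluorescence, with stated times of 30 min and 15 min, tested at 1 uM (on this read-out lower numbers stand for less inhibition and higher numbers for more inhibition at the one concentration tested (going by the name of the read-out)), and gives "not active" (no number reported), so no single number places it among the others. Compound 2, `Cn1c(=O)[nH]c2cc(OCCc3ccccc3)ccc21`, likewise gives "not active" (no number reported) in this assay. For the measured compounds named here, compound 3, `O=C1Nc2ccc(OCc3ccc(Cl)c(Cl)c3)cc2C1=O`, gives 95.7% in this assay, the only numerical reading in the set. The unmeasured compound 4 has structure `CC1(C)C(=O)Nc2ccc(OCCc3ccccc3)cc21`. It differs from compound 1 by phenyl in place of phenoxy on a saturated chain carbon, two bonds along the chain from an oxygen on an aromatic ring. Going by the values given here, no step between measured compounds is available, so the size of this change in this assay cannot be read from the data; because compound 1 gives "not active" (no number reported) and compound 2, carrying the same chain, gives "not active" (no number reported), little inhibition is expected and no step beyond the scatter is anticipated. Compound 4 is expected to give 12% in this assay, within a range from 0% to 40%.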

Compound 4, a percentage reported as inhibition, at one concentration (the size of the read-out at that concentration, not a potency): "not active" (no number reported)
Compound 4: no number reported, and the estimate cannot be compared.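

Compound 1 and compound 4 both come without a number, so no step can be read between them. No measurement shown here bears on this result. The compounds shown leave open how phenyl and phenoxy compare in inhibition.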